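Piperazinyl Replaces Dimethylamino on the Shared Core

This account rests on a few compounds, and the source may have more. Where it says the series, first, only, none or still open, it means among the compounds named here.

Of the compounds shown here, two sharing one core have been measured so far. Compound 1 `COc1cc2c(CN(C)C)coc2cc1C` gives 130000 nM in a functional assay on HEK293 cells for agonist activity at melatonin receptor type 1B (Homo sapiens), read by calcium flux (on this read-out higher numbers stand for an effect only at larger amounts of compound and lower numbers for an effect already at smaller amounts), the lowest of the two numbers seen. Among the measured compounds shown here, compound 2 `COc1cc2c(CN3CCCC3)coc2cc1C` gives 350000 nM in this assay, and the only measured step, a 2.7-fold higher number from compound 1 to compound 2 (0.43 log units; beyond the scatter), is modest and beyond the scatter. Compound 3 `COc1cc2c(CN3CCNCC3)coc2cc1C` has not yet been measured; it differs from compound 1 by piperazin-1-yl in place of dimethylamino on a saturated chain carbon bound to an aromatic carbon. For the measured compounds named here, the one measured step bears on this change, since it too exchanges the dimethylamino for a ring at the same saturated chain carbon. From that step, a higher number is expected for compound 3 than for compound 1, of a size close to that seen for compound 2 and possibly a little larger given the second nitrogen and the added donor counted in the change. The estimated step is a 2.3-fold higher number from compound 1 to compound 3 (0.36 log units; beyond the scatter). Compound 3 is therefore expected to give about 300000 nM in this assay, with a range from 100000 nM to 1000000 nM.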

Compound 3, half-maximal effective concentration: 380000 nM
Beside the measured number, compound 3's estimate is 1.3-fold (0.10 log units) below it; the range from low to high includes it.
By their numbers in this assay, from the lowest: compound 1; then compounds 2 and 3 (each within the scatter of the next).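

At this saturated chain carbon bound to an aromatic carbon, a second ring type also moves the read-out in the same direction as the first: piperazin-1-yl in place of dimethylamino gives a 2.9-fold higher number from compound 1 to compound 3 (0.47 log units; beyond the scatter) in this assay. The exchange of one ring for the other gives a 1.1-fold higher number from compound 2 to compound 3 (0.04 log units; within the scatter), so the six-membered ring with its second nitrogen and its hydrogen-bond donor cannot be told apart from pyrrolidin-1-yl in this read-out, and among these compounds the one clear difference is between dimethylamino and either ring. No measurement is at hand that would explain this pattern.

The three compounds cannot separate the presence of a ring from the larger number of heavy atoms, since both ring groups differ from dimethylamino in both respects; an open-chain diethylamino group at the same carbon would bear on that question. On these data alone, it also remains open whether the ring nitrogen of piperazin-1-yl matters at all, which morpholin-4-yl, with an oxygen in its place, could address, and whether any change at this carbon can bring the number far below that of compound 1.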